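The source may hold more compounds than are shown below. What is called first, only, known or untested is meant among the compounds shown, and "the series" means these compounds.

Of the compounds shown here, three that share one core have been tested in a functional assay on NCI-H1975 cells (Homo sapiens) for inhibition, read by MTT assay, with a stated time of 72 h; on this read-out lower numbers stand for stronger inhibition and higher numbers for weaker inhibition. Compound 1 `CCOc1cc2ncnc(Nc3ccc(F)c(Cl)c3)c2cc1OC(=O)CCl` gives 60 nM. Compound 2 `CCOc1cc2ncnc(Nc3ccc(F)c(Cl)c3)c2cc1OC(=O)CSc1ncccn1` gives 3600 nM, and compound 3 `CCOc1cc2ncnc(Nc3ccc(F)c(Cl)c3)c2cc1OC(=O)CSc1nc2ccccc2s1` gives 9800 nM. Among these three numbers compound 2 stands second highest: the step of a 60-fold higher number from compound 1 to compound 2 (1.78 log units; beyond the scatter) is large, as is a 160-fold higher number from compound 1 to compound 3 (2.21 log units; beyond the scatter), while a 2.7-fold higher number from compound 2 to compound 3 (0.43 log units; beyond the scatter) is modest.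

Compound 4 `CCOc1cc2ncnc(Nc3ccc(F)c(Cl)c3)c2cc1OC(=O)CSc1nc2cc(OC)ccc2s1` has not yet been measured. It differs from compound 2 in one place: 5-methoxy-1,3-benzothiazol-2-yl in place of pyrimidin-2-yl on a sulfur. The measured step that bears most directly on this change is a 2.7-fold higher number from compound 2 to compound 3 (0.43 log units; beyond the scatter), in which the same sulfur received a 1,3-benzothiazol-2-yl group; the number went up modestly there. Going by the values given here, no measured pair separates the 5-methoxy-1,3-benzothiazol-2-yl group from the plain 1,3-benzothiazol-2-yl group, so the expectation rests on compound 3 alone. In this assay a modest rise is therefore expected, with an estimated step of a 2.8-fold higher number from compound 2 to compound 4 (0.44 log units; beyond the scatter). Compound 4 is expected to give about 10000 nM, with a likely range from 3500 nM to 30000 nM.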

Compound 4, half-maximal inhibitory concentration: 3200 nM
Estimate against measurement, compound 4: 3.1-fold (0.49 log units) above; the whole stated range lies above it.
By their numbers in this assay, from the lowest: compound 1; then compounds 4 and 2 (each within the scatter of the next); then compound 3.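

In this assay, going by these compounds alone, the step of a 3.1-fold lower number from compound 3 to compound 4 (0.49 log units; beyond the scatter) is the first measured change made on the fused ring system itself, and it shows that adding methoxy in place of a hydrogen on an aromatic carbon can still shift the number once a 1,3-benzothiazol-2-yl group sits on the sulfur. The step of a 1.1-fold lower number from compound 2 to compound 4 (0.05 log units; within the scatter) leaves the 5-methoxy-1,3-benzothiazol-2-yl and pyrimidin-2-yl groups indistinguishable in this read-out, so more heavy atoms on this sulfur do not by themselves go with a higher number, although compound 3, with its plain 1,3-benzothiazol-2-yl group, does sit above compound 2 beyond the scatter. The methoxy group closes little of the gap to the chloro compound, since the step of a 53-fold higher number from compound 1 to compound 4 (1.73 log units; beyond the scatter) remains large and all the sulfur-linked groups shown stay far from compound 1.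

Still open, on these data alone, is whether an amine or a hydroxyl group in place of the methoxy would shift the number in the same way, and whether bromo in place of chloro on the chain carbon would stay close to compound 1. Nothing measured here explains why these numbers differ.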